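Swapping 1-phenylethyl for 2-methylphenyl at the nitrogen

The source may hold more compounds than are shown below. What is called first, only, known or untested is meant among the compounds shown, and "the series" means these compounds.

Compound 1 (`C[C@@H](Nc1c(NCCCCCC(=O)NO)c(=O)c1=O)c1ccccc1`): 39000000 nM
Compound 2 (`Cc1cccc([C@@H](C)Nc2c(NCCCCCC(=O)NO)c(=O)c2=O)c1`): 82000000 nM

In a physicochemical assay for solubility, with a stated time of 24 h, tested at 30 mg/mL (a higher number here means a more soluble compound, a lower number a less soluble compound), compound 1 stands lowest of the two measured compounds with 39000000 nM and compound 2 gives 82000000 nM on the same scale. The next compound is compound 3 (`Cc1ccccc1Nc1c(NCCCCCC(=O)NO)c(=O)c1=O`), which has not been measured yet. It carries 2-methylphenyl in place of 1-phenylethyl on a nitrogen on an aromatic ring. Among the compounds with values here, only one measured step bears on this, and only loosely. Methyl in place of hydrogen on an aromatic carbon gave a 2.1-fold higher number from compound 1 to compound 2 (0.32 log units; beyond the scatter) and that counts as a modest step. That step leaves the 1-phenylethyl group in place, so the data do not show what replacing this group does. A small upward step at most is therefore expected, and no step beyond the scatter. The expected step is a 1.2-fold higher number from compound 1 to compound 3 (0.06 log units; within the scatter) and its direction is uncertain. For compound 3 the estimate is 45000000 nM with 15000000 nM to 95000000 nM as the expected range.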

Compound 3, solubility: 12000000 nM
Beside the measured number, compound 3's estimate is 3.8-fold (0.57 log units) above it, and the stated range ends above it.
By their numbers in this assay, from the lowest: compound 3; then compound 1; then compound 2.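

At this nitrogen the whole group is replaced for the first time, and in this assay the swap gives a 3.3-fold lower number from compound 1 to compound 3 (0.51 log units; beyond the scatter), whereas the earlier methyl change on the aromatic ring gave a 2.1-fold higher number from compound 1 to compound 2 (0.32 log units; beyond the scatter), so the two single changes shown move the number in opposite directions. The printed counts make the new step notable: 1-phenylethyl and 2-methylphenyl each hold one six-membered aromatic ring of carbon only, with no hydrogen-bond donors or acceptors and no net charge, yet the number still moves beyond the usual scatter, even though the entering group has 7 heavy atoms against 8 and lacks the defined stereocentre. Nothing available explains this drop in the number, so the step stands as an observation only.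

The swap alters several features at once, and the compounds shown cannot separate the loss of the stereocentre from the change in how the ring is attached or from the added methyl. As far as these compounds go, it also remains open how this nitrogen position would respond to an unsubstituted phenyl group, or to a ring carrying an amine or a carboxylic acid.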